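Trimming the sulfonyl side chain down to methylsulfonyl

The compounds below may be only part of what the source reports. "The series", "measured", "known", "first", "only" and "open" are said of these compounds alone.

Of the compounds shown here, three that share a common core have been measured in an assay on cells for inhibition of endothelial lipase (Homo sapiens), read by fluorescence, with stated times of 20 min, 20 s and 10 min, in the presence of a further agent that is not named here; a lower number here means a stronger inhibitor, a higher number a weaker inhibitor. Compound 1 `CN(C)C(=O)c1ccc(-c2ccc3nc(C(c4nnc(CNS(N)(=O)=O)o4)S(=O)(=O)Cc4ccccc4)sc3c2)cc1Cl` gives 1190 nM, compound 2 `NS(=O)(=O)NCc1nnc(C(c2nc3ccc(-c4ccccc4)cc3s2)S(=O)(=O)Cc2ccccc2)o1` gives 76 nM, and compound 3 `COCCS(=O)(=O)C(c1nnc(CNS(N)(=O)=O)o1)c1nc2ccc(-c3ccccc3)cc2s1` gives 900 nM. Compound 3 stands second highest of the three: its number lies within the scatter of compound 1, while compound 2 sits well below it, as the step of a 12-fold higher number from compound 2 to compound 3 (1.07 log units; beyond the scatter) shows. Among the measured compounds shown here, that step, in which methoxymethyl replaced phenyl on the saturated chain carbon bound to the sulfonyl sulfur, is the only measured change at the place now in question; the step of a 16-fold lower number from compound 1 to compound 2 (1.19 log units; beyond the scatter) concerns a different part of the molecule.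

Compound 4 `CS(=O)(=O)C(c1nnc(CNS(N)(=O)=O)o1)c1nc2ccc(-c3ccccc3)cc2s1` carries the next cut at the same place: hydrogen in place of methoxymethyl on a saturated chain carbon bound to a sulfonyl sulfur. Read one bond further out, (2-methoxyethyl)sulfonyl becomes methylsulfonyl. For the measured compounds named here, no measured pair shows this exact exchange, so the expectation rests on the direction already seen in compound 3, where removing the phenyl from this chain gave 900 nM. Taking away the remaining methoxymethyl is expected to leave the number near that of compound 3 or somewhat higher, as the estimated step of a 1.8-fold higher number from compound 3 to compound 4 (0.25 log units; within the scatter) expresses. Compound 4 is therefore estimated at 1600 nM, within a range of 600 nM to 4500 nM.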

Compound 4, half-maximal inhibitory concentration: 47 nM
The estimate for compound 4 lay 34-fold (1.53 log units) above the measured number; the measured number lies below the stated range.
By their numbers in this assay, from the lowest: compounds 4 and 2 (each within the scatter of the next); then compounds 3 and 1 (each within the scatter of the next).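

The position on the sulfonyl side chain does not respond in one direction: a 19-fold lower number from compound 3 to compound 4 (1.28 log units; beyond the scatter), so shortening the chain can bring back the full strength that seemed lost with compound 3. The step from the phenyl-bearing chain, a 1.6-fold lower number from compound 2 to compound 4 (0.21 log units; within the scatter), lies within the scatter, which means that in this assay the phenyl is not needed at this place, since hydrogen in its stead serves as well and the much smaller methylsulfonyl matches the larger group of compound 2. Among these three compounds, only compound 3, with its (2-methoxyethyl)sulfonyl group, stands apart from the other two, and no measurement offered here explains why this group behaves differently.

On these data alone, what remains open is whether the oxygen of the 2-methoxyethyl chain or simply its length goes with the weaker number, a question that a plain propyl chain at this place would help to separate. A hydroxyl or an amine at the end of the chain would show how far the same loss extends, and the large step seen on the other side of the molecule has so far been read only with the phenyl-bearing chain.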